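The source may hold more compounds than are shown below. What is called first, only, known or untested is meant among the compounds shown, and "the series" means these compounds.

Of the compounds shown here, three sharing one core have been measured in an assay on isolated protein for binding affinity to Gonadotropin-releasing hormone receptor (Homo sapiens); on this read-out higher numbers stand for weaker inhibition and lower numbers for stronger inhibition. Compound 1 `Cc1cc2c(cc1Cc1ccc(C(=O)NCC3CCCCC3)o1)C(C)(C)CCC2(C)C` gives 180 nM. Compound 2 `Cc1cc2c(cc1Cc1ccc(C(=O)NC[C@H]3CC[C@H](C(N)=O)CC3)o1)C(C)(C)CCC2(C)C` gives 13 nM, and compound 3 `CCOC(=O)[C@H]1CC[C@H](CNC(=O)c2ccc(Cc3cc4c(cc3C)C(C)(C)CCC4(C)C)o2)CC1` gives 51 nM. Among these three numbers compound 3 stands second highest: the step of a 3.5-fold lower number from compound 1 to compound 3 (0.55 log units; beyond the scatter) separates it from compound 1, and the step of a 3.9-fold higher number from compound 2 to compound 3 (0.59 log units; beyond the scatter) from compound 2.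

Compound 4 `Cc1ccc(CNC(=O)c2ccc(Cc3cc4c(cc3C)C(C)(C)CCC4(C)C)o2)cc1` has not yet been measured. It differs from compound 3 by 4-methylphenyl in place of 4-(ethoxycarbonyl)cyclohexyl on a saturated chain carbon bound to an amide-type nitrogen. For the measured compounds named here, the one measured step that bears on this change is a 3.5-fold lower number from compound 1 to compound 3 (0.55 log units; beyond the scatter). In that step the ethoxycarbonyl enters on a bare saturated ring and the number falls; compound 4 removes that group again. Going by the values given here, the swap of the saturated ring for an aromatic ring carrying a methyl has no measured counterpart here, so the size of that part is unknown. The expectation is therefore a rise of about a 3.9-fold higher number from compound 3 to compound 4 (0.59 log units; beyond the scatter) in this assay, putting compound 4 near compound 1, at an estimated 200 nM, with a range from 60 nM to 700 nM.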

Compound 4, inhibition constant: 83 nM
The estimate for compound 4 lay 2.4-fold (0.38 log units) above the measured number, and the stated range covers the measured number.
By their numbers in this assay, from the lowest: compound 2; then compounds 3 and 4 (each within the scatter of the next); then compound 1.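

In this assay, 4-methylphenyl in place of cyclohexyl on this saturated chain carbon gives a 2.2-fold lower number from compound 1 to compound 4 (0.34 log units; beyond the scatter) and so shows that a number lower than that of compound 1 can be reached here without any carbonyl group on the ring. Against the ester, the change gives a 1.6-fold higher number from compound 3 to compound 4 (0.21 log units; within the scatter) and leaves the two compounds indistinguishable, whereas against the primary amide it gives a 6.4-fold higher number from compound 2 to compound 4 (0.81 log units; beyond the scatter) and leaves the carbamoyl-bearing compound 2 clearly lower. The data shown offer no measurement that explains this order.

From the compounds shown here alone, it remains open how much of the step from compound 1 belongs to the aromatic ring and how much to its methyl, a question a plain phenyl group would address. Also open, going by these compounds, is how a carboxylic acid or an amine would read at the position held by the carbamoyl group.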